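A few compounds are considered here, and "the series" means these few. Any claim that something is new, unique, unknown or untested is made for them only; others in the source may bear on it.

In a functional assay on MDA-MB-231 cells (Homo sapiens) for inhibition, read by sulforhodamine B assay, with a stated time of 48 h (on this read-out higher numbers stand for weaker inhibition of growth and lower numbers for stronger inhibition of growth), compound 2 (`COc1ccc2c(c1)NC(=O)CN2c1nc(COCCCC(=O)NO)nc2ccccc12`) gives 1020 nM, the highest of the three numbers measured. Against it, compound 1 (`COc1ccc2c(c1)NC(=O)CN2c1nc(COC(C)=O)nc2ccccc12`) gives 8.95 nM and compound 3 (`CCCCNc1nc(N2CC(=O)Nc3cc(OC)ccc32)c2ccccc2n1`) gives 7.19 nM, two values within the scatter of each other. Going on to compound 4 (`CCOc1nc(N2CC(=O)Nc3cc(OC)ccc32)c2ccccc2n1`) puts ethoxy in place of (3-(hydroxycarbamoyl)propoxy)methyl on an aromatic carbon between two ring nitrogen atoms: ethoxy in place of (3-(hydroxycarbamoyl)propoxy)methyl on an aromatic carbon. The closest measured parallel, with butylamino entering where the same group leaves, is a 140-fold lower number from compound 2 to compound 3 (2.15 log units; beyond the scatter). The step of a 110-fold higher number from compound 1 to compound 2 (2.06 log units; beyond the scatter) is of similar size, and a 1.2-fold lower number from compound 1 to compound 3 (0.10 log units; within the scatter) stays within the scatter. A large step to a lower number is therefore expected in this assay, estimated as a 100-fold lower number from compound 2 to compound 4 (2.01 log units; beyond the scatter). For compound 4 the expected value is 10 nM, with an estimated range of 3 nM to 35 nM.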

Compound 4, concentration for 50% growth inhibition: 15.4 nM
The estimate for compound 4 lay 1.5-fold (0.19 log units) below the measured number; low and high end bracket the measured number.
By their numbers in this assay, from the lowest: compounds 3, 1 and 4 (each within the scatter of the next, the first and the last beyond it); then compound 2.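

In this assay, ethoxy on the aromatic carbon between two ring nitrogen atoms also recovers the loss seen with (3-(hydroxycarbamoyl)propoxy)methyl, giving a 66-fold lower number from compound 2 to compound 4 (1.82 log units; beyond the scatter), so this recovery does not depend on butylamino alone. Ethoxy and butylamino are separated by a modest step, a 2.1-fold higher number from compound 3 to compound 4 (0.33 log units; beyond the scatter), while the step from acetoxymethyl, a 1.7-fold higher number from compound 1 to compound 4 (0.24 log units; within the scatter), stays within the scatter. Nothing available explains these differences.

The step from butylamino to ethoxy changes both the linking atom and the chain, leaving their contributions unseparated. Ethylamino or butoxy at this position would tell them apart.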